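Chloropropyl amide to chloropropyl urea on a shared sulfonate

The source may hold more compounds than are shown below. What is called first, only, known or untested is meant among the compounds shown, and "the series" means these compounds.

The measured compounds:
Compound 1 `CCCC(=O)Nc1ccc(S(=O)(=O)Oc2ccccc2C(C)C)cc1`: in a functional assay on M21 cells (Homo sapiens) for antiproliferative activity, read by sulforhodamine B assay, with a stated time of 48 h (on this read-out lower numbers stand for stronger inhibition and higher numbers for weaker inhibition), compound 1 gives 6100 nM.
Compound 2 `CC(C)c1ccccc1OS(=O)(=O)c1ccc(NC(=O)CCCCl)cc1`: in this assay compound 2 gives 5100 nM.

Compound 2 carries the lower of the two numbers, but the step of a 1.2-fold lower number from compound 1 to compound 2 (0.08 log units; within the scatter) lies within the scatter, so the two compounds cannot be separated on this read-out; compound 2 is simply one of two near-equal values. Compound 3 `CC(C)c1ccccc1OS(=O)(=O)c1ccc(NC(=O)NCCCCl)cc1` differs from compound 2 by (3-chloropropyl)amino in place of 3-chloropropyl on a carbonyl carbon. Among the measured compounds shown here, only one measured step exists, and it does not touch the carbonyl carbon: a 1.2-fold lower number from compound 1 to compound 2 (0.08 log units; within the scatter) concerns the far end of the chain, and it was within the scatter. For the measured compounds named here, there is thus no measured step bearing directly on the change from compound 2 to compound 3, and the single available step gives no reason to expect movement beyond the scatter. Compound 3 is therefore expected to show the step of a 1.1-fold higher number from compound 2 to compound 3 (0.03 log units; within the scatter), which is no step beyond the scatter. The estimate for compound 3 in this assay is 5500 nM, with a range from 1800 nM to 17000 nM.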

Compound 3, half-maximal inhibitory concentration: 9300 nM
Compound 3: middle estimate off by 1.7-fold (0.23 log units), on the low side; low and high end bracket the measured number.
By their numbers in this assay, from the lowest: compounds 2, 1 and 3 (each within the scatter of the next).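

Among the compounds shown here, this is the first measured change at the carbonyl carbon itself rather than at the far end of the chain: in this assay (3-chloropropyl)amino in place of 3-chloropropyl gives a 1.8-fold higher number from compound 2 to compound 3 (0.26 log units; within the scatter) and (3-chloropropyl)amino in place of propyl gives a 1.5-fold higher number from compound 1 to compound 3 (0.18 log units; within the scatter) on the same carbonyl carbon. Both steps lie within the scatter, so the entering nitrogen, with the hydrogen-bond donor counted for it, does not separate compound 3 from compound 2 or from compound 1, and the amide and urea forms shown cannot be told apart on this read-out. Nothing available explains the values or bears on this result.

The compounds shown leave open whether any group on this carbonyl carbon can move the number beyond the scatter, for instance a longer chain, or an amine or a carboxylic acid at the chain end in place of the chloro group. Also open, on these data alone, is whether the chloro group counts for anything on the urea, a question that a propylamino group in place of (3-chloropropyl)amino would address.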